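Swapping the Sulfonamide Ring: Expected Metabolic Clearance

The source may hold more compounds than are shown below. What is called first, only, known or untested is meant among the compounds shown, and "the series" means these compounds.

Compound 1 `CCn1c([C@@H](C)NS(=O)(=O)c2ccc(Cl)cc2)nc2cccc(Cl)c21` and compound 2 `CCn1c([C@@H](C)NS(=O)(=O)c2cccc(C#N)c2)nc2ccc(C(F)(F)F)cc21` share a core, each carrying a sulfonamide on a different aromatic ring. In an ADME assay (liver) for metabolic stability, with Liver microsome (Homo sapiens) as the target, read by LC-MS, using microsomes and NADPH, with a stated time of 5 min, at 37 degrees C (a higher number here means faster removal of the compound, a lower number slower removal), compound 1 gives > 100 mL.min-1.g-1, which is a limit of the assay rather than a number. In this assay compound 2 likewise gives > 100 mL.min-1.g-1, again a limit and not a measured number. Going by these compounds, both results sit at the limit of > 100 mL.min-1.g-1 in this assay, at which 2 of the 2 values shown sit, so how far compound 2 lies past that point is unknown; it is cleared quickly either way. Compound 3 `CCn1c([C@@H](C)NS(=O)(=O)c2cn(C)c(C)n2)nc2ccc(C(F)(F)F)cc21` has not yet been measured. It differs from compound 2 in one place: 1,2-dimethyl-1H-imidazol-4-yl in place of 3-cyanophenyl on a sulfonyl sulfur. Going by the values given here, no measured step between two compounds exists to guide how large this change might be. The step from compound 2 to compound 3 is expected to be an at least 1.2-fold lower number from compound 2 to compound 3 (0.09 log units; that floor lies within the scatter), a modest move downward. Compound 3 is estimated at 80 mL.min-1.g-1 in this assay, within a range of 35 mL.min-1.g-1 to 160 mL.min-1.g-1.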

Compound 3, intrinsic clearance in microsomes: 43 mL.min-1.g-1
Compound 3: the middle estimate sits 1.9-fold (0.27 log units) above what was measured; the measured number falls inside the stated range.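

Going by these compounds alone, compound 3 is the first compound here to give a number rather than a limit, which shows that clearance can be brought within the measurable range by changing only the group on the sulfonyl sulfur. In this assay, 1,2-dimethyl-1H-imidazol-4-yl in place of 3-cyanophenyl gives an at least 2.3-fold lower number from compound 2 to compound 3 (0.36 log units; beyond the scatter), a change beyond the usual scatter. The true size of this step remains unknown because compound 2 gives only a limit and not a number: the limit of > 100 mL.min-1.g-1 in this assay, at which 2 of the 3 values shown sit.

The compounds shown leave open which feature of the swap matters: the two methyl groups, the ring nitrogens or the loss of the nitrile. A pyridine ring or an imidazole without methyl groups on the sulfonyl sulfur would help to separate these possibilities.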